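Swapping the pyrazole amide for a dimethylimidazole

A few compounds are considered here, and "the series" means these few. Any claim that something is new, unique, unknown or untested is made for them only; others in the source may bear on it.

Of the compounds shown here, three sharing a fluoro-dihydrobenzofuranylmethylamine side chain have been measured in a physicochemical assay for lipophilicity, using the shake flask method, in phosphate buffer, measured as octanol-water partition, with a stated time of 30 min, at pH 7.4; on this read-out lower numbers stand for lower lipophilicity and higher numbers for higher lipophilicity. Compound 1 `CN(C)C(=O)c1cc(-c2cnc(NCc3c(F)ccc4c3CCO4)c3cn[nH]c(=O)c23)n(C)n1` gives 2.1, the highest of the three numbers. Compound 2 `CC1(C)CC(=O)N(c2cnc(NCc3c(F)ccc4c3CCO4)n3cnnc23)C1` gives 2, which lies within the scatter of compound 1. Compound 3 `COCCC(=O)Nc1cnc(NCc2c(F)ccc3c2CCO3)n2cnnc12` gives 1.4, the lowest of the set. Among the measured compounds shown here, the only single-point step among them is a number 0.60 log units lower from compound 2 to compound 3 (beyond the scatter), a modest drop.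

Compound 4 `Cc1ncc(-c2cnc(NCc3c(F)ccc4c3CCO4)c3cn[nH]c(=O)c23)n1C` has not yet been measured in this assay. It differs from compound 1 by 1,2-dimethyl-1H-imidazol-5-yl in place of 3-(dimethylcarbamoyl)-1-methyl-1H-pyrazol-5-yl on an aromatic carbon. For the measured compounds named here, no measured step touches this position or this pair of groups; the step from compound 2 to compound 3 concerns a different substituent on a different core and bears on it only as a gauge of how much one exchange of a ring substituent can move this read-out. With nothing closer to lean on, the expectation for compound 4 is a change of a number 0.10 log units lower from compound 1 to compound 4 (within the scatter) relative to compound 1, which is within the scatter. Compound 4 is therefore estimated at 2, with a range from 1.3 to 2.7.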

Compound 4, distribution coefficient: 1.9
Compound 4: the middle estimate sits 0.10 log units above what was measured, and the stated range covers the measured number.
By their numbers in this assay, from the lowest: compound 3; then compounds 4, 2 and 1 (each within the scatter of the next).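

In this assay, among the compounds shown here, placing 1,2-dimethyl-1H-imidazol-5-yl where 3-(dimethylcarbamoyl)-1-methyl-1H-pyrazol-5-yl stood gives a number 0.20 log units lower from compound 1 to compound 4 (within the scatter) and is the first step read at this position, on an aromatic carbon of the six-membered ring of the shared core. The entering group has fewer heavy atoms than the group that leaves and carries no dimethylcarbamoyl, and even so this exchange does not separate compound 4 from compound 1 on this read-out. No measured information on the two groups is available to account for this result.

The single exchange alters both the five-membered ring and its substituents, so the compounds shown cannot tell apart the contribution of each, and a plain 1-methyl-1H-pyrazol-5-yl group would be needed to divide the two. They also leave open whether this read-out stays as flat at the position with a different kind of group there, such as an aminomethyl group, a carboxylic acid or a longer alkyl chain on the five-membered ring.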